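Chloro step on the benzyl ether series

This account rests on a few compounds, and the source may have more. Where it says the series, first, only, none or still open, it means among the compounds named here.

For the measured compounds named here, in an ADME assay on L929 cells (Mus musculus) for cytotoxicity, read by resazurin assay, with a stated time of 96 h (on this read-out higher numbers stand for lower toxicity in this test and lower numbers for higher toxicity in this test), compound 1 (`Cc1ccccc1COc1ccc([C@H]2S[C@@H](C)C(=O)Nc3[nH]nc(C)c32)cc1`) gives 111000 nM and is the only number so far. In this assay compound 2 (`COc1cc([C@H]2S[C@@H](C)C(=O)Nc3[nH]nc(C)c32)ccc1OCc1ccccc1`) is recorded as "not determined" (no result reported) and has no place on the scale. Compound 3 (`COc1cc([C@H]2S[C@@H](C)C(=O)Nc3[nH]nc(C)c32)ccc1OCc1ccc(Cl)cc1`) is next. The change (chloro in place of hydrogen on an aromatic carbon) puts chloro in place of hydrogen on an aromatic carbon, para to a large group, turning benzyloxy into (4-chlorobenzyl)oxy. Going by the values given here, no measured step exists for this change. A small downward shift in this assay is expected, possibly within the scatter, with compound 1 at 111000 nM as the sole anchor. The estimate for compound 3 is 80000 nM (expected range 30000 nM to 200000 nM).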

Compound 3, concentration lethal to 50% of the cells: 50600 nM
Estimate against measurement, compound 3: 1.6-fold (0.20 log units) above; the measured number falls inside the stated range.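

For the compounds shown here, compound 2 has no number, so no step to compound 3 can be read. The compounds shown leave open how chloro in place of hydrogen shifts the read-out in this assay. No evidence bears on this result.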